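Lengthening the sulfur side chain of compound 3

The compounds below may be only part of what the source reports. "The series", "measured", "known", "first", "only" and "open" are said of these compounds alone.

Measured in a functional assay on PC-3 cells (Homo sapiens) for inhibition, read by MTT assay, with a stated time of 48 h; a higher number here means a weaker inhibitor, a lower number a stronger inhibitor:
- compound 1 `COc1ccc(-n2c(SCc3ccccc3)nnc2-c2cc(OC)c(OC)c(OC)c2)cc1`: 34100 nM
- compound 2 `COc1cc(-c2nnc(S)n2-c2ccc(N(C)C)cc2)cc(OC)c1OC`: > 60000 nM (a limit of the assay, not a number)
- compound 3 `COc1cc(-c2nnc(SCc3ccccc3)n2-c2ccc(N(C)C)cc2)cc(OC)c1OC`: 55800 nM

For the measured compounds named here, compound 1 and compound 3 carry the only two true numbers here, and these lie within the scatter of each other. For compound 2 the assay gave only a limit, so the comparison with it is loose.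

The next structure is compound 4 `COc1ccc(C(=O)CSc2nnc(-c3cc(OC)c(OC)c(OC)c3)n2-c2ccc(N(C)C)cc2)cc1`. It differs from compound 3 in one place: (4-methoxyphenyl)carbonyl in place of phenyl on a saturated chain carbon bound to a sulfur. In words, (4-methoxyphenyl)carbonyl stands in place of phenyl on a saturated chain carbon bound to a sulfur. Going by the values given here, no measured compound carries this group, so the data give no direct size for the change.

Among the compounds with values here, two measured steps offer the only guidance. Placing benzyl in place of hydrogen on the sulfur gave an at least 1.0-fold lower number from compound 2 to compound 3 (0.03 log units; that floor lies within the scatter), and this step touches the same sulfur. Placing dimethylamino in place of methoxy on an aromatic carbon gave a 1.6-fold higher number from compound 1 to compound 3 (0.21 log units; within the scatter). Neither step goes beyond the scatter, so no step beyond the scatter is expected in this assay. The estimated step is a 1.4-fold lower number from compound 3 to compound 4 (0.14 log units; within the scatter). For compound 4 the expected value is 40000 nM, with an estimated range of 12000 nM to 60000 nM.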

Compound 4, half-maximal inhibitory concentration: 22000 nM
For compound 4 the middle estimate is 1.8-fold (0.26 log units) above the measured one, and the stated range covers the measured number.
By their numbers in this assay, from the lowest: compounds 4, 1 and 3 (each within the scatter of the next, the first and the last beyond it). At a limit, above all of these: compound 2.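

In this assay, the sulfur side chain now shows a change that reaches beyond the scatter: replacing the phenyl of the benzyl group with (4-methoxyphenyl)carbonyl gives a 2.5-fold lower number from compound 3 to compound 4 (0.40 log units; beyond the scatter). Benzyl on this sulfur gave no step beyond the scatter, whereas ((4-methoxyphenyl)carbonyl)methyl on the same sulfur gives an at least 2.7-fold lower number from compound 2 to compound 4 (0.43 log units; beyond the scatter), so the identity of the group on the sulfur matters here, not merely the presence of one. The value for compound 2 is a limit and not a number, which makes this second step a floor rather than a true size: the limit of > 60000 nM in this assay, at which 1 of the 4 values shown sits.

Compound 4 brings in a carbonyl and a methoxy group together, and the compounds shown do not separate what each contributes to the lower number. Also open, as far as these compounds go, is whether an amine, a carboxylic acid or a longer chain on the same sulfur would lower the number further, and whether the new side chain would give a similar step with methoxy in place of dimethylamino on the aromatic ring.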